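Exchanging the 3-methylthiophen-2-yl group of compound 1

This account rests on a few compounds, and the source may have more. Where it says the series, first, only, none or still open, it means among the compounds named here.

Measured in a functional assay on K562 cells (Homo sapiens) for cytotoxicity, read by ELISA, with a stated time of 4 days; on this read-out higher numbers stand for weaker inhibition and lower numbers for stronger inhibition:
compound 1 `Cc1ccsc1-c1cc(-c2ccoc2)cc(-c2ccco2)n1`: 23300 nM
compound 2 `Cc1ccsc1-c1cc(-c2ccoc2)cc(-c2ccc(Cl)cc2)n1`: 19600 nM
compound 3 `Clc1ccc(-c2cc(-c3ccco3)cc(-c3ccc(Cl)s3)n2)cc1`: 10500 nM

Compound 1 stands at the upper end of these three numbers, and only compound 3 lies clearly under it. Compound 4 `Clc1ccc(-c2cc(-c3ccoc3)cc(-c3ccco3)n2)s1` is not yet measured. It differs from compound 1 by 5-chlorothiophen-2-yl in place of 3-methylthiophen-2-yl on an aromatic carbon, with 5-chlorothiophen-2-yl in place of 3-methylthiophen-2-yl next to the ring nitrogen. For the measured compounds named here, the one measured single-place step, a 1.2-fold lower number from compound 1 to compound 2 (0.08 log units; within the scatter), concerns another place on the core and offers only weak guidance. Compound 3 also carries 5-chlorothiophen-2-yl and gives 10500 nM, but it differs elsewhere too. A small move toward lower numbers is therefore expected in this assay, perhaps none beyond the scatter. The expected change is a 1.7-fold lower number from compound 1 to compound 4 (0.22 log units; within the scatter). Compound 4 is estimated at 14000 nM, with an expected range of 7000 nM to 28000 nM.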

Compound 4, half-maximal inhibitory concentration: 16200 nM
Compound 4: middle estimate off by 1.2-fold (0.06 log units), on the low side; measured number inside the range.
By their numbers in this assay, from the lowest: compounds 3, 4, 2 and 1 (each within the scatter of the next, the first and the last beyond it).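

For the compounds shown here, exchanging 3-methylthiophen-2-yl for 5-chlorothiophen-2-yl next to the ring nitrogen, tested in this assay, gives the first single-place reading at this position (a 1.4-fold lower number from compound 1 to compound 4 (0.16 log units; within the scatter)). Compounds 1 and 4 therefore cannot be told apart on this read-out, so a chlorine on the five-membered ring in place of the methyl-bearing group leaves the number within the scatter. No evidence at hand bears on this result. From the compounds shown here alone, it remains open whether an amine or a carboxylic acid at this position would give a number beyond the scatter.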